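A few compounds are considered here, and "the series" means these few. Any claim that something is new, unique, unknown or untested is made for them only; others in the source may bear on it.

Measured compounds in a functional assay on the whole organism (Tail, strain ICR) with Mus musculus as the target, in the tail flick test, with a stated time of 150 min, at a dose of 25 umol/kg by the oral route; a lower number here means a weaker effect, a higher number a stronger effect of the compound at the dose given:
compound 1, `C[C@H](NC(=O)CN(c1nc(Cl)nc2[nH]cnc12)C1CC1)C(=O)OCc1ccccc1`: 23%
compound 2, `N=C(N)NCCC[C@H](NC(=O)CN(c1nc(Cl)nc2[nH]cnc12)C1CC1)C(=O)OCc1ccccc1`: 6.12%
compound 3, `CC[C@H](C)[C@H](NC(=O)CN(c1ncnc2c1ncn2C1CCCCO1)C1CC1)C(=O)OCc1ccccc1`: 16.4%

Compound 3 gives the second highest of the three numbers in this assay. Its nearest neighbour is compound 1, whose value lies higher but within the scatter, so the two cannot be told apart; its furthest is compound 2, whose value lies lower by more than the scatter. Among the measured compounds shown here, the only step between two measured compounds that differ in one place is the change a number 16.9 percentage points lower from compound 1 to compound 2 (beyond the scatter), which concerns a different part of the molecule and a different kind of group from the change now considered.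

Compound 4, `CSCC[C@H](NC(=O)CN(c1ncnc2c1ncn2C1CCCCO1)C1CC1)C(=O)OCc1ccccc1`, is to be measured in this assay. It differs from compound 3 by 2-(methylsulfanyl)ethyl in place of sec-butyl on a saturated chain carbon bound to an amide-type nitrogen and a carbonyl carbon. For the measured compounds named here, no measured pair isolates this exchange, so nothing in the data speaks for a shift in either direction; the single step measured elsewhere does not bear on it. The expected step is therefore one within the scatter: a number 1.4 percentage points lower from compound 3 to compound 4 (within the scatter). Compound 4 is estimated to give 15% in this assay, with a range from 4% to 28%.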

Compound 4, a percentage reported as activity, at one dose (the size of the read-out at that dose, not a potency): 17.5%
Beside the measured number, compound 4's estimate is 2.5 percentage points below it; the range from low to high includes it.
By their numbers in this assay, from the lowest: compound 2; then compounds 3, 4 and 1 (each within the scatter of the next).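

In this assay, 2-(methylsulfanyl)ethyl in place of sec-butyl on a saturated chain carbon bound to an amide-type nitrogen and a carbonyl carbon gives a number 1.1 percentage points higher from compound 3 to compound 4 (within the scatter), so this exchange, the first measured on the core shared by compound 3 and compound 4, cannot be told from no effect. Among the compounds shown here, the one earlier step, a number 16.9 percentage points lower from compound 1 to compound 2 (beyond the scatter), put a larger group in place of a hydrogen atom on a different core, whereas here the two chains have the same heavy-atom count, with a sulfur atom and a hydrogen-bond acceptor entering, and this swap leaves the read-out at this dose within the usual scatter. No independent measurement is available to explain this result.

As far as these compounds go, whether an amine, a carboxylic acid or a longer chain at this carbon would move the number beyond the scatter remains open. From the compounds shown here alone, it is also open whether the same exchange would give a similar step on the core of compound 1, and whether the two chains would still match at other doses or times, since the data cover a single dose and a single time.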